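Toward compound 3: diethoxy chain on the aminomethyl phenol

The source may report more compounds than this note shows. Statements on the series, on what has been measured and on what is new or still open speak of the compounds shown alone.

Measured in an ADME assay on MDA-MB-231 cells (Homo sapiens) for inhibition, read by MTT assay, with a stated time of 24 h; on this read-out lower numbers stand for stronger inhibition and higher numbers for weaker inhibition:
- compound 1 `CC(C)=CCC[C@H](C)c1ccc(C)c(CNCCO)c1O`: > 20000 nM (a limit)
- compound 2 `CCOC(CCN1COc2c([C@@H](C)CCC=C(C)C)ccc(C)c2C1)OCC`: > 20000 nM (a limit)

Compound 1 stands at the limit of > 20000 nM in this assay, at which 2 of the 2 values shown sit, which is a limit and not a number. Compound 3 `CCOC(CCNCc1c(C)ccc([C@@H](C)CCC=C(C)C)c1O)OCC` is the next to be read, with diethoxymethyl in place of hydroxy on a saturated chain carbon, two bonds along the chain from an amine nitrogen. With compound 2, which also holds a 3,3-diethoxypropyl chain, at > 20000 nM, a limit, no step beyond the scatter is expected in this assay. The estimated step runs a number no higher from compound 1 to compound 3 (the limit leaves the size open). Compound 3 is expected at 20000 nM, with an estimated range of 9000 nM to 40000 nM.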

Compound 3, half-maximal inhibitory concentration: > 20000 nM
Compound 3: only a limit was reported; the forecaster's own chance of this, stated with the estimate: 60%; the middle value lies on the limit itself.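

In this assay no step can be read between compound 1 and compound 3, as both values are limits and not numbers: the limit of > 20000 nM in this assay, at which 3 of the 3 values shown sit.

The compounds shown leave open whether diethoxymethyl in place of hydroxy changes inhibition at all, since none of the three gives a number.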